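A few compounds are considered here, and "the series" means these few. Any claim that something is new, unique, unknown or untested is made for them only; others in the source may bear on it.

Measured in a functional assay on CEM-DNR-bulk cells (Homo sapiens), read by MTT assay, with a stated time of 72 h; on this read-out lower numbers stand for stronger inhibition and higher numbers for weaker inhibition:

- Compound 1 `C#Cc1cn([C@@H]2O[C@H](CO)[C@@H](O)[C@H]2O)c2ncnc(N(C)C)c12`: 240 nM
- Compound 2 `Cc1nc(N)c2c(-c3ccoc3)cn([C@@H]3O[C@H](CO)[C@@H](O)[C@H]3O)c2n1`: > 20000 nM (a limit)
- Compound 3 `Nc1nc2c(c(-c3ccccc3)cn2[C@@H]2O[C@H](CO)[C@@H](O)[C@H]2O)c(=O)[nH]1`: > 20000 nM (a limit)

Compound 2 stands at the limit of > 20000 nM in this assay, at which 2 of the 3 values shown sit, and the other compound there is compound 3. Its entry is a limit and not a number, so it fixes no exact starting point. Only compound 1 has a numerical value, 240 nM.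

The next compound is compound 4 `Cc1nc(N)c2c(I)cn([C@@H]3O[C@H](CO)[C@@H](O)[C@H]3O)c2n1`, which carries iodo in place of furan-3-yl on an aromatic carbon. For the measured compounds named here, no measured pair shows this change. A moderate step towards stronger inhibition in this assay is expected, though with low confidence, and a second reading at the limit remains possible. The estimated change is an at least 5.0-fold lower number from compound 2 to compound 4 (0.69 log units; beyond the scatter). For compound 4 the expected value is 4000 nM, with an estimated range from 500 nM to 20000 nM.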

Compound 4, half-maximal inhibitory concentration: 3480 nM
Estimate against measurement, compound 4: 1.1-fold (0.06 log units) above; low and high end bracket the measured number.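

In this assay, for the compounds shown here, the place two ring bonds from the ring nitrogen proves able to bring this core off the limit: iodo in place of furan-3-yl gives an at least 5.7-fold lower number from compound 2 to compound 4 (0.75 log units; beyond the scatter) and yields the first number for a compound with this substitution. Going by these compounds alone, a single iodine thus reads better here than the five-membered aromatic ring, which the earlier compounds could not show, since none of them formed a pair differing in one place. Compound 2 is a limit and not a number, so the step has a lower bound only: the limit of > 20000 nM in this assay, at which 2 of the 4 values shown sit.

The compounds shown leave open how far the read-out follows the group at this place, as one pair gives no trend. From the compounds shown here alone, how a smaller halogen such as bromo, or an aminomethyl group, would read there on the same core remains unknown.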